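Oral tail flick: a single side-chain exchange on the shared core

A few compounds are considered here, and "the series" means these few. Any claim that something is new, unique, unknown or untested is made for them only; others in the source may bear on it.

In a functional assay on the whole organism (Tail, strain ICR) with Mus musculus as the target, in the tail flick test, with a stated time of 60 min, at a dose of 25 umol/kg by the oral route (a higher number here means a stronger effect of the compound at the dose given, a lower number a weaker effect), two compounds have been measured so far. Compound 1 `CC(C)C[C@H](NC(=O)CN(c1nc(Cl)nc2[nH]cnc12)C1CC1)C(=O)OCc1ccccc1` gives 27.3%. Compound 2 `NC(=O)C[C@H](NC(=O)CN(c1nc(Cl)nc2[nH]cnc12)C1CC1)C(=O)O` gives 43.1%, the higher of the two numbers, and its gap to compound 1 lies beyond the scatter of repeated measurements. Nothing more can be read from this pair, as the two structures differ in more than one place.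

Compound 3 `CC(C)C[C@H](NC(=O)CN(c1nc(Cl)nc2[nH]cnc12)C1CC1)C(=O)O` has not yet been measured in this assay. Its difference from compound 2 is a single exchange: isopropyl in place of carbamoyl on a saturated chain carbon, two bonds along the chain from an amide-type nitrogen and a carbonyl carbon. Going by the values given here, compound 2 is the only measured compound that shares the carboxylic acid end with compound 3, and compound 1 shares the isobutyl chain with it.

With no one-step comparison available, the direction of the change cannot be called from the data. The author expects a modest step downward, from compound 2 to compound 3 of a number 8.1 percentage points lower from compound 2 to compound 3 (within the scatter), with the usual scatter easily covering it. Compound 3 is therefore estimated at 35%, within a range from 15% to 55%.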

Compound 3, a percentage reported as activity, at one dose (the size of the read-out at that dose, not a potency): 36.4%
The estimate for compound 3 lay 1.4 percentage points below the measured number; the measured number falls inside the stated range.
By their numbers in this assay, from the lowest: compounds 1, 3 and 2 (each within the scatter of the next, the first and the last beyond it).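

In this assay, the exchange of carbamoyl for isopropyl on a saturated chain carbon, two bonds along the chain from an amide-type nitrogen and a carbonyl carbon, amounts to a number 6.7 percentage points lower from compound 2 to compound 3 (within the scatter) and so cannot be told from repeated measurement at this dose. The exchange of benzyl for hydrogen on an oxygen next to a carbonyl group, read as a number 9.1 percentage points higher from compound 1 to compound 3 (within the scatter) in the same test, also stays inside that scatter, so compound 3 joins two compounds whose direct gap lies beyond it by two single exchanges, neither of which can be separated from the scatter on its own. No available measurement bears on the reason for these small steps.

On these data alone, whether another group at the chain position, such as an amine or a hydroxyl group, would give a step beyond the scatter remains open. Because each number is a read-out at one dose and one stated time, the compounds also leave open how potency or the time course would compare across compound 1, compound 2 and compound 3.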